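Working notes: from propargyl to benzyl

The compounds below may be only part of what the source reports. "The series", "measured", "known", "first", "only" and "open" are said of these compounds alone.

Compound 1 `CCCCCOC(=O)Nc1nc(=O)n(C2O[C@H](C(=O)O)[C@@H](O)[C@H]2O)cc1F`: 0.03 ug/mL
Compound 2 `C#CCOC(=O)Nc1nc(=O)n(C2O[C@H](C(=O)O)[C@@H](O)[C@H]2O)cc1F`: 0.007 ug/mL
Compound 3 `O=C(Nc1nc(=O)n(C2O[C@H](C(=O)O)[C@@H](O)[C@H]2O)cc1F)OCc1ccccc1`: not yet measured

Within the data shown here, in a functional assay on SK-MEL-2 cells (Homo sapiens) for inhibition (a higher number here means a weaker inhibitor, a lower number a stronger inhibitor), compound 2, at 0.007 ug/mL, holds the lower of the two numbers so far, and its gap to compound 1 lies beyond the scatter. The next structural change is phenyl in place of ethynyl on a saturated chain carbon bound to an oxygen next to a carbonyl group. In words, this is phenyl in place of ethynyl on a saturated chain carbon bound to an oxygen next to a carbonyl group, or propargyloxy to benzyloxy.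

Among the measured compounds shown here, only one measured step bears on this, at the same place: a 4.3-fold lower number from compound 1 to compound 2 (0.63 log units; beyond the scatter). For the measured compounds named here, that modest step shows the number responds to the group carried there, but no aromatic group has yet been measured at this place. With compound 2 at the low end of a two-compound series, a move to a higher number is the more likely direction, of about the same modest size, though a result within the scatter remains possible. The expected change is a 2.6-fold higher number from compound 2 to compound 3 (0.41 log units; beyond the scatter). For compound 3 the estimated value is 0.018 ug/mL, with an expected range from 0.005 ug/mL to 0.06 ug/mL.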

Compound 3, half-maximal inhibitory concentration: 0.1 ug/mL
For compound 3 the middle estimate is 5.6-fold (0.74 log units) below the measured one, and the stated range ends below it.
By their numbers in this assay, from the lowest: compound 2; then compound 1; then compound 3.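

The aromatic group gives the first move upward at this place: in this assay, phenyl in place of ethynyl on a saturated chain carbon bound to an oxygen next to a carbonyl group produces a 14-fold higher number from compound 2 to compound 3 (1.15 log units; beyond the scatter), a large step. Phenyl in place of butyl at the same carbon also produces a 3.3-fold higher number from compound 1 to compound 3 (0.52 log units; beyond the scatter), so compound 3 carries the highest number of the three and the group order runs ethynyl, butyl, phenyl, with every gap beyond the scatter. The compounds thus show that this place can separate a strong inhibitor from a clearly weaker one, but no measured data explain why phenyl stands at the weak end.

With only one aromatic group shown, it remains open whether the higher number belongs to aromatic rings in general or to phenyl alone; a cyclohexyl or pyridyl group at this carbon would separate those readings. On these data alone, it is also open whether the same order of ethynyl, butyl and phenyl would hold with a methyl ester in place of the carboxylic acid on the shared core.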